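A few compounds are considered here, and "the series" means these few. Any claim that something is new, unique, unknown or untested is made for them only; others in the source may bear on it.

Measured so far in an ADME assay on HEL cells (Homo sapiens) for cytotoxicity, read by cell counting, with a stated time of 3 days; a higher number here means that more compound is tolerated, a lower number that less compound is tolerated:
compound 1 `O=c1[nH]c(=O)n([C@H]2C[C@H](O)[C@@H](CO)O2)cc1-c1cn(-c2c(F)cccc2F)nn1` gives >= 10000 nM
compound 2 `O=c1[nH]c(=O)n([C@H]2C[C@H](O)[C@@H](CO)O2)cc1-c1cnnn1-c1c(F)cccc1F` gives > 100000 nM

The value for compound 2 is a limit of this assay, not a number; it sits at the limit of > 100000 nM in this assay, at which 1 of the 2 values shown sits. The value for compound 1 is likewise a limit, at the limit of >= 10000 nM in this assay, at which 1 of the 2 values shown sits. Compound 2 thus stands at the top of what this assay reports, with no defined figure. Compound 3 `CC(C)c1ccc(-n2nncc2-c2cn([C@H]3C[C@H](O)[C@@H](CO)O3)c(=O)[nH]c2=O)cc1` differs from compound 2 by 4-isopropylphenyl in place of 2,6-difluorophenyl on an aromatic nitrogen. No measured step links two of these compounds, so no size of effect is known here. The step from compound 2 to compound 3 is expected to be an at least 1.2-fold lower number from compound 2 to compound 3 (0.09 log units; that floor lies within the scatter), a small shift within or barely beyond the scatter. Compound 3 is expected at 80000 nM, range 20000 nM to 200000 nM, likely again reported only as a limit.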

Compound 3, minimum cytotoxic concentration: > 100000 nM
Compound 3 was reported as a limit; the forecaster's own chance of this, stated with the estimate: 70%; at least 1.2-fold (0.09 log units) between middle value and limit.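

In this assay compound 3 gives > 100000 nM, a limit and not a number. Going by these compounds alone, compound 2 gives > 100000 nM, also a limit, so no step between compound 2 and compound 3 can be read. As far as these compounds go, whether 4-isopropylphenyl in place of 2,6-difluorophenyl changes tolerance at all remains open.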